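Series notes: exchange of the ring-bearing side group on compound 1

This account rests on a few compounds, and the source may have more. Where it says the series, first, only, none or still open, it means among the compounds named here.

Among the compounds with values here, compound 1 `CC(C)C(c1ccc(-c2ccc3cccc(F)c3c2)[nH]c1=O)N1CCN/C1=N\C#N` in a physicochemical assay for solubility, measured as kinetic solubility, at pH 2 (on this read-out lower numbers stand for lower solubility and higher numbers for higher solubility), gives 32500 nM; no measured compound gives a larger number, and only compound 3 is separated from it beyond the scatter. Compound 2 `CC(C)C(Cc1noc(=O)[nH]1)c1ccc(-c2ccc3cccc(F)c3c2)[nH]c1=O` in this assay gives 18200 nM, and compound 3 `Cc1c[nH]c(C(c2ccc(-c3ccc4cccc(F)c4c3)[nH]c2=O)C(C)C)n1` in this assay gives 6300 nM. The measured steps are a 1.8-fold lower number from compound 1 to compound 2 (0.25 log units; within the scatter), a 5.2-fold lower number from compound 1 to compound 3 (0.71 log units; beyond the scatter) and a 2.9-fold lower number from compound 2 to compound 3 (0.46 log units; beyond the scatter).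

Compound 4 `CC(C)C(/C=C1\CCNC1=O)c1ccc(-c2ccc3cccc(F)c3c2)[nH]c1=O` is not yet measured. Relative to compound 1 the change is a group of 7 heavy atoms (5 carbon, 1 nitrogen, 1 oxygen; one five-membered non-aromatic ring with 1 hetero atom) in place of a group of 8 heavy atoms (4 carbon, 4 nitrogen; one five-membered non-aromatic ring with 2 hetero atoms), on a saturated chain carbon bound to an aromatic carbon and a saturated chain carbon. Both measured steps that start from compound 1 exchange the same group at the same place, and both gave lower numbers, one within the scatter and one modest. The entering group of compound 4 carries fewer hetero atoms than any of the three groups compared so far, which adds uncertainty but no contrary evidence. A modest lowering is therefore expected, a 3.0-fold lower number from compound 1 to compound 4 (0.47 log units; beyond the scatter). For compound 4 in this assay the estimate is 11000 nM, with a range from 3500 nM to 33000 nM.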

Compound 4, solubility: 23600 nM
Beside the measured number, compound 4's estimate is 2.1-fold (0.33 log units) below it; measured number inside the range.
By their numbers in this assay, from the lowest: compound 3; then compounds 2, 4 and 1 (each within the scatter of the next).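

At this place, on a saturated chain carbon bound to an aromatic carbon and a saturated chain carbon, this assay shows that the group with one five-membered non-aromatic ring with 1 hetero atom cannot be told apart from the group of compound 1 (a 1.4-fold lower number from compound 1 to compound 4 (0.14 log units; within the scatter)) or from that of compound 2 (a 1.3-fold higher number from compound 2 to compound 4 (0.11 log units; within the scatter)). Only the group of compound 3 stands apart (a 3.7-fold higher number from compound 3 to compound 4 (0.57 log units; beyond the scatter)), and an aromatic ring alone does not mark that difference, since compound 2 also carries one. No measurement shown accounts for this spread.

Going by these compounds, an amine or a carboxylic acid at this place remains open, as does whether either would leave the span set by compound 3 and compound 1. On these data alone, whether a longer chain between this carbon and the ring alters the picture also remains open.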